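This account rests on a few compounds, and the source may have more. Where it says the series, first, only, none or still open, it means among the compounds named here.

Compound 1 `CCCCCn1nc(C(=O)N[C@H]2COc3ccccc3N(C)C2=S)nc1Cc1ccccc1` is the reference point of this small series. In a toxicity assay on HT-29 cells (Homo sapiens) for cytotoxicity (on this read-out lower numbers stand for higher toxicity in this test and higher numbers for lower toxicity in this test), compound 1 gives only a limit, > 100000 nM. Compound 2 `CN1C(=S)[C@@H](NC(=O)c2nc(Cc3ccccc3)n(CCCF)n2)COc2ccccc21` is its closest measured neighbour. In this assay compound 2 likewise gives only a limit, > 100000 nM. For the measured compounds named here, the single step between measured compounds, a step that the two limits leave unreadable from compound 1 to compound 2, is therefore of unreadable size. What the measured data do establish is the limit of > 100000 nM in this assay, at which 2 of the 2 values shown sit.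

Compound 3 `CN1C(=S)[C@@H](NC(=O)c2nc(Cc3ccccc3)n(CCCCCC#N)n2)COc2ccccc21` is the unmeasured member. It differs from compound 1 by cyano in place of hydrogen on a saturated chain carbon, five bonds along the chain from an aromatic nitrogen. Going by the values given here, no measured step bears directly on this change; the only step available, which exchanges fluoro for ethyl on a saturated chain carbon three bonds along the chain from an aromatic nitrogen, left both ends at the limit, so no size can be taken from it. Both measured compounds sitting at the limit gives no reason to expect compound 3 to fall below it. Compound 3 is therefore expected to stay at the limit in this assay as well, with the step that the limit leaves unreadable from compound 1 to compound 3 estimated to be none beyond the scatter. The estimate for compound 3 is 150000 nM, within 60000 nM to 500000 nM.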

Compound 3, half-maximal cytotoxic concentration: > 100000 nM
Compound 3 ended at the assay's limit; the forecaster's own chance of this, stated with the estimate: 85%; the middle value lies beyond the limit too.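

In this assay compound 3 gives > 100000 nM, which is a limit of the assay. For the compounds shown here, no step among compound 1, compound 2 and compound 3 can be read. The compounds shown leave open whether any chain on the aromatic nitrogen would bring a measurable value within reach: the limit of > 100000 nM in this assay, at which 3 of the 3 values shown sit.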